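This account rests on a few compounds, and the source may have more. Where it says the series, first, only, none or still open, it means among the compounds named here.

Compound 1 `FC(F)(F)c1cccc(NC(=S)Nc2ccc(I)cc2)c1` in an ADME assay on MT4 cells (Homo sapiens) for cytotoxicity (on this read-out higher numbers stand for lower toxicity in this test and lower numbers for higher toxicity in this test), gives 10000 nM.
Compound 2 `FC(F)(F)c1cccc(NC(=S)NCc2ccco2)c1` in this assay gives 43000 nM.
Compound 3 `FC(F)(F)c1cccc(NC(=S)Nc2ccccc2Br)c1` in this assay gives 36000 nM.

Compound 3 sits with compound 2 at the upper end of the three numbers, the two within the scatter of each other, and apart from compound 1 by a 3.6-fold higher number from compound 1 to compound 3 (0.56 log units; beyond the scatter). Compound 4 `CSCCCNC(=S)Nc1cccc(C(F)(F)F)c1` differs from compound 3 by 3-(methylsulfanyl)propyl in place of 2-bromophenyl on an amide-type nitrogen. The step bearing most directly on this is a 1.2-fold lower number from compound 2 to compound 3 (0.08 log units; within the scatter), which lay within the scatter, so one swap of the group on this nitrogen away from 2-bromophenyl changed little. The modest steps of a 4.3-fold higher number from compound 1 to compound 2 (0.63 log units; beyond the scatter) and a 3.6-fold higher number from compound 1 to compound 3 (0.56 log units; beyond the scatter) both move away from compound 1 and do not involve compound 3 as a starting point. No step beyond the scatter is therefore expected in this assay. Compound 4 is estimated at 40000 nM, range 18000 nM to 90000 nM, meaning an expected step of a 1.1-fold higher number from compound 3 to compound 4 (0.05 log units; within the scatter).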

Compound 4, half-maximal cytotoxic concentration: 43000 nM
Compound 4: the middle estimate sits 1.1-fold (0.03 log units) below what was measured, within the range that was stated.
By their numbers in this assay, from the lowest: compound 1; then compounds 3, 2 and 4 (each within the scatter of the next).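

In this assay, for the compounds shown here, a group with no ring, 3-(methylsulfanyl)propyl, on the amide-type nitrogen reads level with the ring-bearing groups of the earlier compounds: a 1.2-fold higher number from compound 3 to compound 4 (0.08 log units; within the scatter) and no change at the digits printed from compound 2 to compound 4 (within the scatter) both lie within the scatter. Compound 1 alone stands apart, with a 4.3-fold higher number from compound 1 to compound 4 (0.63 log units; beyond the scatter) beyond the scatter. No measured evidence accounts for these numbers. Open, going by these compounds, is whether an amine or a carboxylic acid at the end of a longer chain on this nitrogen would stay with compounds 2, 3 and 4 in this assay.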